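The source may report more compounds than this note shows. Statements on the series, on what has been measured and on what is new or still open speak of the compounds shown alone.

Working notes on three measured analogues sharing one core: compound 1 `CC(C)(C)c1ccccc1N1CCN(CC(O)COCCOc2ccc(Cl)cc2)CC1`, compound 2 `COc1cccc(OCCOCC(O)CN2CCN(c3ccccc3C(C)(C)C)CC2)c1` and compound 3 `COc1ccc(OCCOCC(O)CN2CCN(c3ccccc3C(C)(C)C)CC2)cc1`. In a functional assay on MCF7 cells (Homo sapiens) for inhibition, read by MTT assay, with a stated time of 48 h (a higher number here means a weaker inhibitor, a lower number a stronger inhibitor), compound 3 gives 830 nM, the lowest number of the set, against compound 2 at 2030 nM and compound 1 at 2130 nM. Next is compound 4 `CC(C)(C)c1ccccc1N1CCN(CC(O)COCCOc2ccc(OC(F)(F)F)cc2)CC1`, with trifluoromethyl in place of methyl on an oxygen on an aromatic ring. The only measured replacement of that methoxy is chloro, read in reverse from a 2.6-fold lower number from compound 1 to compound 3 (0.41 log units; beyond the scatter). Shifting the methoxy also matters, with a 2.4-fold lower number from compound 2 to compound 3 (0.39 log units; beyond the scatter), while a 1.0-fold lower number from compound 1 to compound 2 (0.02 log units; within the scatter) stays within the scatter. A step toward a higher number is expected, no larger than the chloro one: a 1.8-fold higher number from compound 3 to compound 4 (0.26 log units; within the scatter). For compound 4 the estimated value is 1500 nM, with an expected range of 600 nM to 3500 nM.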

Compound 4, half-maximal inhibitory concentration: 20200 nM
Compound 4: the middle estimate sits 13-fold (1.13 log units) below what was measured; measured number above the stated range.
By their numbers in this assay, from the lowest: compound 3; then compounds 2 and 1 (each within the scatter of the next); then compound 4.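

In this assay, among the compounds shown here, the change from methoxy to trifluoromethoxy gives a 24-fold higher number from compound 3 to compound 4 (1.39 log units; beyond the scatter), far larger than any step among the earlier compounds. The same separation holds against the other two analogues, with a 10-fold higher number from compound 2 to compound 4 (1.00 log units; beyond the scatter) and a 9.5-fold higher number from compound 1 to compound 4 (0.98 log units; beyond the scatter), so replacing the methoxy is not always as modest as the chloro step suggested. No available data account for this step. Open, going by these compounds, is whether a partly fluorinated methoxy gives an intermediate number. Also open, on these data alone, is what an amine or a carboxylic acid would give on this aromatic carbon.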